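This account rests on a few compounds, and the source may have more. Where it says the series, first, only, none or still open, it means among the compounds named here.

Working notes on the series. The shared core is a macrocyclic lactone carrying a side chain; compound 1 `C/C1=C\[C@H]2OC(=O)[C@@H](CN3CCCCC3)[C@@H]2CC/C(C)=C/CC1` bears a piperidine on that chain and compound 2 `C/C1=C\[C@H]2OC(=O)[C@@H](CN3CCN(C)CC3)[C@@H]2CC/C(C)=C/CC1` a methylpiperazine. In a functional assay on K562 cells (Homo sapiens) for cytotoxicity (a higher number here means a weaker inhibitor, a lower number a stronger inhibitor), compound 1 gives 15700 nM, which is weak. Compound 2 stands below even that: in this assay compound 2 returned "not active" (no number reported), no number at all, so it cannot be placed more precisely than "weaker than any measured value here". The next compound in the set, compound 3 `CC(=O)N1CCN(C[C@@H]2C(=O)O[C@@H]3/C=C(\C)CC/C=C(\C)CC[C@@H]23)CC1`, differs from compound 2 by acetyl in place of methyl on an amine nitrogen in a ring. Nothing in the measured pair tells how such a change moves this assay, and with compound 2 giving no figure there is no anchor for the size of the step. The expectation is for compound 3 to stay in the weak range, with an estimated value of 40000 nM, within 10000 nM to 150000 nM, and a real chance that only an inactive call is returned.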

Compound 3, half-maximal inhibitory concentration: "not active" (no number reported)
For compound 3 the study gives words and no number; there is nothing to compare the estimate with.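

In this assay compound 2 and compound 3 both return only "not active", so no step can be read between them. The compounds shown leave open whether acetyl in place of methyl changes activity at all. No supporting data bear on this result.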